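A few compounds are considered here, and "the series" means these few. Any claim that something is new, unique, unknown or untested is made for them only; others in the source may bear on it.

Compound 2 `COc1ccc(NS(=O)(=O)/C=C/c2c(F)c(F)c(F)c(F)c2F)cc1` and compound 1 `COc1ccc(NS(=O)(=O)/C=C/c2c(F)c(F)c(F)c(F)c2F)cc1F` share a core and differ by one change, (fluoro in place of hydrogen on an aromatic carbon). In a functional assay on DU-145 cells (Homo sapiens) for cytotoxicity, read by trypan blue exclusion, with a stated time of 96 h (on this read-out higher numbers stand for weaker inhibition and lower numbers for stronger inhibition), compound 2 gives 10000 nM, and in this assay compound 1 gives 10000 nM, so the step of no change at the digits printed from compound 2 to compound 1 (within the scatter). Compound 3 `COC(=O)C(Nc1cc(NS(=O)(=O)/C=C/c2c(OC)cc(OC)cc2OC)ccc1OC)c1ccccc1` is built on a different core, and the difference between the two cores is not broken down here; in this assay compound 3 gives 2500 nM, the lowest of the three numbers, beyond the scatter from both compound 1 and compound 2. Compound 4 `COC(=O)C(Nc1cc(NS(=O)(=O)/C=C/c2c(OC)cc(OC)cc2OC)ccc1OC)c1ccc(F)cc1` is not yet measured and differs from compound 3 by fluoro in place of hydrogen on an aromatic carbon. Among the compounds with values here, this is the same kind of change as the one from compound 2 to compound 1, though not the same: there the fluoro entered ortho to a methoxy group and meta to a large group, here it enters para to a large group. Since the earlier step was no change at the digits printed from compound 2 to compound 1 (within the scatter), compound 4 is expected to show a step of no change at the digits printed from compound 3 to compound 4 (within the scatter), with a single precedent behind it. Compound 4 is therefore estimated at 2500 nM, between 1200 nM and 5500 nM.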

Compound 4, half-maximal inhibitory concentration: 2500 nM
Compound 4: the middle estimate sits on the measured number at the digits printed, and the stated range covers the measured number.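

In this assay, fluoro in place of hydrogen on an aromatic carbon gives no change at the digits printed from compound 3 to compound 4 (within the scatter), and set beside the earlier step, the change carries over from one core to the other: the same change on two cores in this assay, no change at the digits printed (within the scatter) from compound 2 to compound 1 and no change at the digits printed (within the scatter) from compound 3 to compound 4, 1.0-fold (0.00 log units) apart, within the scatter of two such steps The agreement holds on two cores that stand at different levels in this assay, and with the fluoro at a different place on each, para to a large group in compound 4. Within the data shown here, it rests on only two pairs, however, so it does not show that the change would be equally silent on a further core or at another carbon of these rings, and a step within the scatter does not show that the fluoro has no effect on anything other than this read-out.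

What the compounds shown leave open is whether a larger group, such as chloro, methyl or trifluoromethyl, would read the same as fluoro on the phenyl ring of compound 3. From the compounds shown here alone, it also remains open how that core would respond to a carboxylic acid in place of the methoxycarbonyl group, or to an amine on that ring.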